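Chloro Substitution on a Fused Core and Cell Toxicity

The compounds below may be only part of what the source reports. "The series", "measured", "known", "first", "only" and "open" are said of these compounds alone.

Of the compounds shown here, three have been tested in a functional assay on T47D cells (Homo sapiens) for cytotoxicity, read by sulforhodamine B assay, with a stated time of 48 h; on this read-out higher numbers stand for lower toxicity in this test and lower numbers for higher toxicity in this test. Compound 1 `ClCc1cccc(Cn2cnc3c(Cl)ncnc32)c1` carries a chloro group on its core. In this assay compound 1 returns > 100000 nM, which is a limit of the assay and not a number. Compound 2 `ClCc1cccc(Cn2cnc3c(Cl)nc(Cl)nc32)c1` differs from compound 1 by one change, (chloro in place of hydrogen on an aromatic carbon). In this assay compound 2 likewise returns > 100000 nM, again a limit rather than a number. The step that the two limits leave unreadable from compound 1 to compound 2 therefore cannot be sized; the relevant reading is the limit of > 100000 nM in this assay, at which 2 of the 3 values shown sit. Compound 3 `ClCc1ccccc1Cn1cnc2ncnc(Cl)c21` has the same atoms as compound 1 joined differently, and the difference between the two cores is not broken down here. In this assay, within the data shown here, compound 3 gives 4260 nM, the only true number among the three.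

Compound 4 `ClCc1ccccc1Cn1cnc2nc(Cl)nc(Cl)c21` has not yet been measured. It differs from compound 3 by chloro in place of hydrogen on an aromatic carbon, the same change that separates compound 1 from compound 2; the place of the change reads the same in both pairs. What that change did in the first pair cannot be read from compound 1 and compound 2. The expectation for compound 4 therefore rests mainly on the measured value of compound 3, 4260 nM, with wide room on either side. The estimated step is a 1.4-fold higher number from compound 3 to compound 4 (0.15 log units; within the scatter). Compound 4 is expected to fall near 6000 nM, within the range 1500 nM to 40000 nM.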

Compound 4, concentration lethal to 50% of the cells: > 100000 nM
Compound 4: a limit, no number (the forecaster's own chance of this, stated with the estimate: 15%); middle value at least 16-fold (1.22 log units) from the limit.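

On the core of compound 3, chloro in place of hydrogen on an aromatic carbon, here between two ring nitrogen atoms, gives an at least 23-fold higher number from compound 3 to compound 4 (1.37 log units; beyond the scatter) in this assay, so on this read-out the added chloro group goes with lower toxicity in this test, and the size of the step is a minimum rather than a measured distance. In this assay compound 4 gives > 100000 nM, which is a limit and not a number. The same change on the core of compound 1 cannot be read, so the series does not show whether the change carries from one core to the other with a similar size, or even in the same direction, and the two pairs share only their end point: the limit of > 100000 nM in this assay, at which 3 of the 4 values shown sit.

What the compounds shown leave open is whether the large step in this assay belongs to chloro itself or would also appear with an amine or a methoxy group on that same aromatic carbon of the core of compound 3. Also open, from the compounds shown here alone, is what an amine or a methoxy group there would do on the core of compound 1, where the parent compound already sits at a limit.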